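From 4-fluorophenyl to 3-fluorophenyl, with only limits to go on

The compounds below may be only part of what the source reports. "The series", "measured", "known", "first", "only" and "open" are said of these compounds alone.

Of the compounds shown here, three sharing one core have been tested in an ADME assay on HepG2 cells (Homo sapiens) for cytotoxicity, read by MTT assay, with a stated time of 72 h; on this read-out higher numbers stand for lower toxicity in this test and lower numbers for higher toxicity in this test. Compound 1 (`COc1ccc(-c2cc(Cl)cn3c([N+](=O)[O-])c(CS(=O)(=O)c4ccccc4)nc23)cc1`) gives > 3900 nM, which is a limit and not a number. Compound 2 (`N#Cc1ccc(-c2cc(Cl)cn3c([N+](=O)[O-])c(CS(=O)(=O)c4ccccc4)nc23)cc1`) gives > 3900 nM, also a limit. Compound 3 (`O=[N+]([O-])c1c(CS(=O)(=O)c2ccccc2)nc2c(-c3ccc(F)cc3)cc(Cl)cn12`) gives > 15600 nM, again a limit. With no true number among the three, compound 3 cannot be ranked against the others.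

Compound 4 (`O=[N+]([O-])c1c(CS(=O)(=O)c2ccccc2)nc2c(-c3cccc(F)c3)cc(Cl)cn12`) differs from compound 3 by a single change: 3-fluorophenyl in place of 4-fluorophenyl on an aromatic carbon. In words, 3-fluorophenyl stands in place of 4-fluorophenyl. The closest measured comparisons are a step that the two limits leave unreadable from compound 1 to compound 3 and a step that the two limits leave unreadable from compound 2 to compound 3, along with a step that the two limits leave unreadable from compound 1 to compound 2. None of these has a readable size, and none moves a fluoro group, so they offer no sign of a real change. In this assay, no step beyond the scatter is therefore expected, and the estimated change is a step that the limit leaves unreadable from compound 3 to compound 4. Compound 4 is expected at 16000 nM, with an estimated range of 5000 nM to 40000 nM.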

Compound 4, half-maximal cytotoxic concentration: > 12500 nM
Compound 4 ended at the assay's limit (the forecaster's own chance of this, stated with the estimate: 75%); the middle value is on the limit's open side.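

In this assay, for the compounds shown here, compound 4 gives only a limit, as do compound 1, compound 2 and compound 3, so no step from any of them to compound 4 can be read. As far as these compounds go, whether 3-fluorophenyl in place of 4-fluorophenyl changes toxicity in this assay at all stays open.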